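Iodo in Place of Ethynyl on Two Nucleoside Cores

The compounds below may be only part of what the source reports. "The series", "measured", "known", "first", "only" and "open" are said of these compounds alone.

Compound 1 `C#Cc1cn([C@@H]2O[C@H](CO)[C@@H](O)[C@H]2O)c2nc(C)nc(N)c12` carries an ethynyl group on its core. In a functional assay on HCT-116 cells (Homo sapiens), read by MTT assay, with a stated time of 72 h (a higher number here means a weaker inhibitor, a lower number a stronger inhibitor), compound 1 is reported only as a limit, > 20000 nM. Compound 2 `Cc1nc(N)c2c(I)cn([C@@H]3O[C@H](CO)[C@@H](O)[C@H]3O)c2n1` carries iodo in place of ethynyl, a change counted as iodo in place of ethynyl on an aromatic carbon. In this assay compound 2 likewise appears only as a limit, > 20000 nM. The step from compound 1 to compound 2 is therefore a step that the two limits leave unreadable from compound 1 to compound 2; because of the limit of > 20000 nM in this assay, at which 2 of the 3 values shown sit, the two values give no reading of its direction or size.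

Compound 3 `C#Cc1cn([C@@H]2O[C@H](CO)[C@@H](O)[C@H]2O)c2ncnc(OC)c12` sits on a second core; how that core differs from the core of compound 1 is not broken down here. In this assay, going by the values given here, compound 3 gives 5140 nM, the only number among the three measured values.

Compound 4 `COc1ncnc2c1c(I)cn2[C@@H]1O[C@H](CO)[C@@H](O)[C@H]1O` is to compound 3 what compound 2 is to compound 1: the change is iodo in place of ethynyl on an aromatic carbon, and it sits at the same place on the same kind of ring, so it is the same change made on a second core. The earlier step, from compound 1 to compound 2, left no readable size, so the expectation for compound 4 rests mainly on the number for compound 3, 5140 nM, with room for the change to move it either way. The step from compound 3 to compound 4 is expected to be about a 1.6-fold higher number from compound 3 to compound 4 (0.19 log units; within the scatter). Compound 4 is therefore estimated at 8000 nM in this assay, between 2500 nM and 25000 nM.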

Compound 4, half-maximal inhibitory concentration: > 20000 nM
Compound 4: no number, only a limit; the forecaster's own chance of this, stated with the estimate: 35%; at least 2.5-fold (0.39 log units) between middle value and limit.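

In this assay compound 4 is reported only as a limit, > 20000 nM. From the compounds shown here alone, on the second core, putting iodo in place of ethynyl gives an at least 3.8-fold higher number from compound 3 to compound 4 (0.59 log units; beyond the scatter), so on this core the ethynyl compound is the stronger of the pair, and the true size of the step remains open beyond what is printed. This does not show that the change carries from one core to the other, since a step that can be read exists on the second core alone, while the pair on the core of compound 1 gives no direction or size, and the steps that end at a limit stay incomplete because of where the values sit: the limit of > 20000 nM in this assay, at which 3 of the 4 values shown sit.

The compounds shown leave open whether another group on the same aromatic carbon, such as an amine, a nitrile or a longer chain, would keep, lower or raise the number of compound 3, 5140 nM. They also leave open how far compound 4 really lies past its limit, and whether iodo and ethynyl differ at all on the core of compound 1.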